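This account rests on a few compounds, and the source may have more. Where it says the series, first, only, none or still open, it means among the compounds named here.

Compound 1, `CCCN(CCC)S(=O)(=O)c1ccc(S(=O)(=O)N2CCC[C@@H](C(=O)OCC)C2)cc1`, gives 2300 nM in a functional assay on MIA PaCa-2 cells (Homo sapiens) for inhibition, read by MTT assay, with a stated time of 7 days; a lower number here means a stronger inhibitor, a higher number a weaker inhibitor.
Compound 2, `CCOC(=O)[C@H]1CCN(S(=O)(=O)c2ccc(S(=O)(=O)N(CC)CC)cc2)C1`, gives 29200 nM in this assay.
Compound 3, `CC(C)c1noc(N2CCN(C(=O)[C@@H]3CCCN(S(=O)(=O)c4ccc(S(=O)(=O)C5CCC5)cc4)C3)CC2)n1`, gives 70 nM in this assay.

Within the data shown here, of the three compounds measured so far, compound 3 has the lowest number in this assay. Its nearest neighbour is compound 1, whose number is higher by a gap that lies beyond the usual scatter, and compound 2 stands furthest away, with a still larger gap that is also beyond the scatter. Compound 3 thus stands apart from the other two as the strongest inhibitor among them.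

Compound 4, `CCC(CC)S(=O)(=O)c1ccc(S(=O)(=O)N2CCC[C@@H](C(=O)N3CCN(c4nc(C(C)C)no4)CC3)C2)cc1`, keeps everything in compound 3 except one group: pentan-3-yl in place of cyclobutyl on a sulfonyl sulfur. Among the measured compounds shown here, no pair of measured compounds shows this change, so there is no step on record to lean on. The group that leaves and the group that enters are both built of carbon only, and the count of heavy atoms moves by one. An exchange of this kind is expected to leave the result close to where compound 3 stands, so the step of a 1.3-fold higher number from compound 3 to compound 4 (0.11 log units; within the scatter) is expected to be small, if anything a slight weakening, and not clearly beyond the scatter. For compound 4 the estimate in this assay is 90 nM, with a range from 30 nM to 270 nM.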

Compound 4, half-maximal inhibitory concentration: 50 nM
Estimate against measurement, compound 4: 1.8-fold (0.26 log units) above, and the stated range covers the measured number.
By their numbers in this assay, from the lowest: compounds 4 and 3 (each within the scatter of the next); then compound 1; then compound 2.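

The exchange of cyclobutyl for pentan-3-yl on a sulfonyl sulfur gives, in this assay, a 1.4-fold lower number from compound 3 to compound 4 (0.15 log units; within the scatter), so the two compounds cannot be told apart in this assay. Among these compounds, compounds 1, 2 and 3 differ from one another in more than one place, so this pair gives the first reading of a single change: at this place, and on this core, the four-membered ring of carbon only can give way to an open group without a change that stands out from the scatter. Nothing on record explains why the value holds across this exchange.

Going by these compounds, the leaving and entering groups are both built of carbon only, so it remains open how this place would respond to a group with other atoms, such as an amine or a carboxylic acid, or to a longer chain such as n-octyl. On these data alone, it also remains open whether the same exchange would give a similarly small step on a different core, such as that of compound 1.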